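Branched alkyl cyanoguanidines: an added methyl on the chain

A few compounds are considered here, and "the series" means these few. Any claim that something is new, unique, unknown or untested is made for them only; others in the source may bear on it.

Compound 1 `CC(C)C(C)(C)/N=C(\NC#N)Nc1cccnc1` and compound 2 `CCC(C)(CC)/N=C(\NC#N)Nc1cccnc1` differ in their core by 1-ethyl-1-methylpropyl in place of 1,1,2-trimethylpropyl on a double-bonded nitrogen. In a functional assay on the whole organism (blood, strain Wistar-Okamoto) with Rattus norvegicus as the target, with a stated time of 5 days (on this read-out lower numbers stand for an effect already at smaller amounts and higher numbers for an effect only at larger amounts of compound), compound 1 gives 1 mg/kg, and compound 2 gives 0.5 mg/kg; the step is a 2.0-fold lower number from compound 1 to compound 2 (0.30 log units; within the scatter). Compound 3 `CC(C)(C)C(C)(C)/N=C(\NC#N)Nc1cccnc1` carries methyl in place of hydrogen on a saturated chain carbon bound to three saturated chain carbons; compound 3 gives 50 mg/kg, so that a 50-fold higher number from compound 1 to compound 3 (1.70 log units; beyond the scatter). Compound 4 `CCC(CC)(CC)/N=C(\NC#N)Nc1cccnc1` is not yet measured and carries methyl in place of hydrogen on a saturated chain carbon, two bonds along the chain from a double-bonded nitrogen. This is the same kind of change as from compound 1 to compound 3, not the same: there the place is a saturated chain carbon bound to three saturated chain carbons, here a saturated chain carbon, two bonds along the chain from a double-bonded nitrogen. For compound 4 a step of a 10-fold higher number from compound 2 to compound 4 (1.00 log units; beyond the scatter) is expected, smaller than the earlier one. The expectation rests on compound 3 giving 50 mg/kg after the same kind of addition, while the place differs. Compound 4 is estimated at 5 mg/kg, between 1 mg/kg and 50 mg/kg.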

Compound 4, minimum effective dose: 1 mg/kg
Compound 4: the middle estimate sits 5.0-fold (0.70 log units) above what was measured, within the range that was stated.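

In this assay the added methyl on a saturated chain carbon, two bonds along the chain from a double-bonded nitrogen, gives a 2.0-fold higher number from compound 2 to compound 4 (0.30 log units; within the scatter). The size of this kind of change does not carry from one core to the other: the same change on two cores in this assay, a 50-fold higher number (1.70 log units; beyond the scatter) from compound 1 to compound 3 and a 2.0-fold higher number (0.30 log units; within the scatter) from compound 2 to compound 4, 25-fold (1.40 log units) apart, beyond the scatter of two such steps. This rests on two pairs with the methyl at different places, so it shows no general rule for the series and does not separate an effect of the core from one of the place.

Going by these compounds, whether a methyl at one matched place would give the same step on both cores remains open. Also open, on these data alone, is how a longer chain, such as propyl, or an amine on the chain would read out here.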